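The source may hold more compounds than are shown below. What is called first, only, known or untested is meant among the compounds shown, and "the series" means these compounds.

Of the compounds shown here, two have so far been measured in a physicochemical assay for lipophilicity, in phosphate buffer, measured as octanol-water partition, at pH 11.5; on this read-out higher numbers stand for higher lipophilicity and lower numbers for lower lipophilicity. Compound 1 `CCCCNC(=N)NC(=N)Nc1ccc(Cl)cc1` gives 3.13, the lower of the two numbers, while compound 2 `CCCCCCNC(=N)NC(=N)Nc1ccc(C(F)(F)F)cc1` gives 4.31. Compound 3 `CC(C)OC(=N)NC(=N)Nc1ccc(Cl)cc1` is still to be measured. It differs from compound 1 in one place: isopropoxy in place of butylamino on a carbon with a double bond to nitrogen. Going by the values given here, no pair of measured compounds shows a comparable change, so the expectation rests on the change itself, in which isopropoxy, the smaller group, enters in place of butylamino. A moderate drop, a number 0.63 log units lower from compound 1 to compound 3 (beyond the scatter), is expected, beyond the usual scatter. Compound 3 is estimated at 2.5, between 1.9 and 3.1.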

Compound 3, partition coefficient: 2.64
Beside the measured number, compound 3's estimate is 0.14 log units below it, and the stated range covers the measured number.
By their numbers in this assay, from the lowest: compound 3; then compound 1; then compound 2.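

In this assay, isopropoxy in place of butylamino on a carbon with a double bond to nitrogen gives a number 0.49 log units lower from compound 1 to compound 3 (beyond the scatter), so the read-out does respond to the group at this position. The entering group has fewer heavy atoms and brings a hydrogen-bond acceptor where the leaving group had a hydrogen-bond donor, so these differences arrive together. Nothing available explains the step. Isopropylamino or butoxy at this position could help separate the role of the linking atom from that of the chain. Going by these compounds, whether the same change gives a similar step with the other groups of compound 2 remains open.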